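Hydroxy for dimethylamino on the terminal ring of compound 1

This account rests on a few compounds, and the source may have more. Where it says the series, first, only, none or still open, it means among the compounds named here.

Among the measured compounds shown here, compound 1 `Cc1ccc2[nH]c(-c3ccc(-c4ccc(-c5ccc(N(C)C)cc5)cc4)cc3)nc2c1` has the lower of the two numbers so far in a functional assay on KB cells (Homo sapiens) for inhibition, read by sulforhodamine B assay; a lower number here means a stronger inhibitor of growth, a higher number a weaker inhibitor of growth: compound 1 gives 6240 nM. For the measured compounds named here, the only measured neighbour is compound 2 `CN(C)c1ccc(-c2ccc(-c3ccc(-c4nc5ccccc5[nH]4)cc3)cc2)cc1`, which in this assay gives 39300 nM; the step of a 6.3-fold higher number from compound 1 to compound 2 (0.80 log units; beyond the scatter) shows that the series responds to a small change at the core. The next compound, compound 3 `Cc1ccc2[nH]c(-c3ccc(-c4ccc(-c5ccc(O)cc5)cc4)cc3)nc2c1`, keeps the core of compound 1 and changes the far end: hydroxy in place of dimethylamino on an aromatic carbon. Going by the values given here, no measured step concerns this end of the molecule, so the dimethylamino-to-hydroxy exchange has no direct precedent here; the step from compound 1 to compound 2 only shows that single-group changes can move the number well beyond the scatter. On that basis a modest weakening is expected, a 1.9-fold higher number from compound 1 to compound 3 (0.28 log units; within the scatter), with wide uncertainty in either direction. Compound 3 is therefore estimated at 12000 nM in this assay, within a range of 3000 nM to 50000 nM.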

Compound 3, concentration for 50% growth inhibition: 21200 nM
Estimate against measurement, compound 3: 1.8-fold (0.25 log units) below, within the range that was stated.
By their numbers in this assay, from the lowest: compound 1; then compounds 3 and 2 (each within the scatter of the next).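

Among the compounds shown here, this is the first measured change at the far end of the molecule: in this assay, hydroxy in place of dimethylamino on an aromatic carbon, para to a large group, gives a 3.4-fold higher number from compound 1 to compound 3 (0.53 log units; beyond the scatter). The far end therefore affects growth inhibition in this assay, and with the core of compound 1 held constant, the 4-(dimethylamino)phenyl end goes with the lower number of this pair. Together with a 6.3-fold higher number from compound 1 to compound 2 (0.80 log units; beyond the scatter), this gives one step beyond the scatter at each of the two changed places, although the data shown contain nothing that bears on what lies behind either step.

This single exchange replaces the dimethylamino nitrogen and its carbons with one oxygen, so it cannot separate the loss of the dimethylamino group from the entry of the hydroxy group; a methoxy or a primary amino group at the same place would bear on that question. Also open, from the compounds shown here alone, is whether the hydroxy-for-dimethylamino step keeps its direction and size on the core of compound 2, which lacks the methyl group.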